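One Substituent Swap, One Estimate

The source may hold more compounds than are shown below. What is called first, only, known or untested is meant among the compounds shown, and "the series" means these compounds.

Compound 1 `CN(Cc1ccc(N(C)C)cc1)Cc1cccc(CNc2ccnc3cc(Cl)ccc23)c1` gives 9.67
Compound 2 `CN(Cc1ccccc1)Cc1ccc(CNc2ccnc3cc(Cl)ccc23)cc1` gives 9.9
Compound 3 `CN(Cc1ccc(N(C)C)cc1)Cc1ccccc1CNc1ccnc2cc(Cl)ccc12` gives 9.71

In a physicochemical assay for acid dissociation, compound 1 at 9.67 stands within the usual scatter of both other compounds, and those two lie within the scatter of each other as well. These numbers therefore do not separate the three compounds.

Compound 4 `CN(Cc1ccc(Cl)cc1)Cc1cccc(CNc2ccnc3cc(Cl)ccc23)c1` has not yet been measured. It keeps the core of compound 1 and differs in one place, with chloro in place of dimethylamino on an aromatic carbon para to a large group (chloro in place of dimethylamino on an aromatic carbon). Cut one bond further out, 4-(dimethylamino)benzyl becomes 4-chlorobenzyl.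

Among the compounds with values here, no two measured compounds differ in one place only, so nothing here shows this swap directly. The expectation rests instead on how closely the values sit: compound 2 at 9.9 and compound 3 at 9.71 stay within the scatter of compound 1 although their structures are not the same. The expected step (a number 0.03 log units higher from compound 1 to compound 4 (within the scatter)) stays within the scatter of this assay, with a higher read-out expected no more than a lower one. For compound 4 the estimate is 9.7 with an expected range from 9.35 to 10 in this measurement.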

Compound 4, acid dissociation constant: 9.89
The estimate for compound 4 lay 0.19 log units below the measured number; low and high end bracket the measured number.
By their numbers in this assay, from the lowest: compounds 1, 3, 4 and 2 (each within the scatter of the next).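

In this assay, within the data shown here, compounds 1 and 4 form the first pair that differs in one place, so this swap can now be read directly instead of being inferred from compounds with different structures: chloro in place of dimethylamino on an aromatic carbon, para to a large group, gives a number 0.22 log units higher from compound 1 to compound 4 (within the scatter). At this position, then, 4-(dimethylamino)benzyl and 4-chlorobenzyl cannot be told apart by this read-out, even though the two groups differ in their heavy atoms and in their count of hydrogen-bond acceptors. No measurement is available that bears on why the two compounds sit so close.

The compounds shown leave open whether a carboxylic acid or a longer chain on this same aromatic carbon would also stay within the scatter of compound 1. They also leave open whether the same swap on compound 3, which carries the 4-(dimethylamino)benzyl group as well, would give a step of similar size.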